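The source may report more compounds than this note shows. Statements on the series, on what has been measured and on what is new or still open speak of the compounds shown alone.

Measured so far:
compound 1 `NC(=O)Cc1cc(=O)oc2cc(OCc3cccc(O)c3)ccc12` — 4270 nM
compound 2 `NC(=O)Cc1cc(=O)oc2cc(OCc3cccnc3)ccc12` — 21000 nM

In an assay (strain Wistar) for inhibition of Amine oxidase [flavin-containing] A (Rattus norvegicus) (on this read-out higher numbers stand for weaker inhibition and lower numbers for stronger inhibition), compound 1 gives 4270 nM. In this assay, for the measured compounds named here, compound 2 gives 21000 nM, the highest of the two numbers; its only neighbour is compound 1, and the move is a 4.9-fold higher number from compound 1 to compound 2 (0.69 log units; beyond the scatter). Compound 3 `NC(=O)Cc1cc(=O)oc2cc(OCc3ccncc3)ccc12` is not yet measured. It differs from compound 2 by pyridin-4-yl in place of pyridin-3-yl on a saturated chain carbon bound to an oxygen on an aromatic ring. Going by the values given here, the single measured step, a 4.9-fold higher number from compound 1 to compound 2 (0.69 log units; beyond the scatter), exchanges a different group on that saturated chain carbon bound to an oxygen on an aromatic ring and does not compare two isomers of one ring, so it gives no direct guide to this change. With nothing of that kind to draw on, the expectation is a move no larger than the scatter, in either direction. The estimated step is a 1.1-fold lower number from compound 2 to compound 3 (0.02 log units; within the scatter). Compound 3 is expected at 20000 nM, with a range from 7000 nM to 55000 nM.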

Compound 3, half-maximal inhibitory concentration: 26500 nM
Estimate against measurement, compound 3: 1.3-fold (0.12 log units) below; low and high end bracket the measured number.
By their numbers in this assay, from the lowest: compound 1; then compounds 2 and 3 (each within the scatter of the next).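

In this assay the step of a 1.3-fold higher number from compound 2 to compound 3 (0.10 log units; within the scatter) lies within the scatter, so on a saturated chain carbon bound to an oxygen on an aromatic ring, pyridin-4-yl and pyridin-3-yl are not told apart. The step of a 6.2-fold higher number from compound 1 to compound 3 (0.79 log units; beyond the scatter) lies beyond the scatter in the same direction as the earlier 4.9-fold higher number from compound 1 to compound 2 (0.69 log units; beyond the scatter), so the higher number on leaving 3-hydroxyphenyl is not tied to one pyridine isomer. No measurement here speaks to the reason for either result.

The compounds shown leave open whether pyridin-2-yl would also fall with these two isomers. They also leave open whether the hydroxyl of 3-hydroxyphenyl matters to the lower number of compound 1, a question that plain phenyl and 3-methoxyphenyl at this place would address.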